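One Trifluoromethyl in Place of Two Chlorines

A few compounds are considered here, and "the series" means these few. Any claim that something is new, unique, unknown or untested is made for them only; others in the source may bear on it.

Compound 1 `COc1cc(-c2nn(-c3cccc(NC(=O)Nc4cc(C(F)(F)F)cc(C(F)(F)F)c4)c3)cc2-c2ccncc2)ccc1Cl` and compound 2 `COc1cc(-c2nn(-c3cccc(NC(=O)Nc4ccc(Cl)c(Cl)c4)c3)cc2-c2ccncc2)ccc1Cl` share a core and differ only in the group on the amide-type nitrogen. In a functional assay on NCI-H322M cells (Homo sapiens) for inhibition, read by sulforhodamine B assay, with a stated time of 48 h (a higher number here means that more compound is tolerated, a lower number that less compound is tolerated), compound 1 gives 29900 nM. Compound 2 reaches only a limit of this assay, > 50000 nM, which is the point described by the limit of > 50000 nM in this assay, at which 1 of the 2 values shown sits. Compound 3 `COc1cc(-c2nn(-c3cccc(NC(=O)Nc4cccc(C(F)(F)F)c4)c3)cc2-c2ccncc2)ccc1Cl` has not yet been measured. It differs from compound 2 in one place: 3-(trifluoromethyl)phenyl in place of 3,4-dichlorophenyl on an amide-type nitrogen. Within the data shown here, no step between two measured compounds is available to size this change. The step of an at least 1.1-fold lower number from compound 2 to compound 3 (0.04 log units; that floor lies within the scatter) is expected to lie within the scatter, if it exists at all. Compound 3 is estimated at about 45000 nM in this assay. The expected range for compound 3 runs from 20000 nM to 60000 nM, with a real chance that only a limit is reported again.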

Compound 3, concentration lethal to 50% of the cells: > 50000 nM
Compound 3 was reported as a limit; the forecaster's own chance of this, stated with the estimate: 50%; at least 1.1-fold (0.04 log units) between middle value and limit.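

Both compound 2 and compound 3 sit at a limit of this assay, so the swap of 3,4-dichlorophenyl for 3-(trifluoromethyl)phenyl cannot be sized, because neither compound has a readable number: the limit of > 50000 nM in this assay, at which 2 of the 3 values shown sit.

The new compound does allow one readable comparison. Hydrogen in place of trifluoromethyl on an aromatic carbon gives an at least 1.6-fold higher number from compound 1 to compound 3 (0.22 log units; that floor lies within the scatter), so the true step may be larger, but what is printed does not establish a change beyond the scatter.

Going by these compounds, the true values of compound 2 and compound 3 remain open, as does whether these two groups differ at all in this assay. Also open, on these data alone, is whether a nitrile, an amine or a carboxylic acid on that aromatic ring would give a readable number.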